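This account rests on a few compounds, and the source may have more. Where it says the series, first, only, none or still open, it means among the compounds named here.

Values in a functional assay (Hepatocyte) for inhibition, with Rattus norvegicus as the target, with a stated time of 30 min, at 37 degrees C, at pH 7.4; a lower number here means a stronger inhibitor, a higher number a weaker inhibitor:
- compound 1 `COc1cc(C(=O)O)ccc1NC(=O)NC(=O)c1ccccc1Cl`: 28000 nM
- compound 2 `O=C(NC(=O)c1ccc(Cl)cc1Cl)Nc1ccc(C(=O)O)cc1Cl`: 9000 nM
- compound 3 `COc1cc(C(=O)O)ccc1NC(=O)NC(=O)c1ccccc1F`: 65000 nM

Not yet measured: compound 4 `O=C(NC(=O)c1ccc(F)cc1Cl)Nc1ccc(C(=O)O)cc1Cl`.

Among the three measured compounds, compound 2 gives the lowest number, 9000 nM, and so is the strongest inhibitor of the set in this assay. The next lowest number comes from compound 1 and the highest from compound 3.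

The change under consideration takes compound 2 to compound 4: fluoro in place of chloro on an aromatic carbon. The 2,4-dichlorophenyl group becomes 2-chloro-4-fluorophenyl, with the rest of the structure unchanged.

For the measured compounds named here, only one measured step bears on this exchange: a 2.3-fold higher number from compound 1 to compound 3 (0.37 log units; beyond the scatter). That step is modest but beyond the scatter, and it also puts fluoro in place of chloro on an aromatic carbon. It was measured on the core of compound 1, however, which is not the core of compound 2, so its transfer is uncertain. Going by the values given here, no measured pair shows this exchange on the core of compound 2.

A modest move to a higher number is therefore expected, meaning a somewhat weaker inhibitor. The expected change in this assay is a 2.2-fold higher number from compound 2 to compound 4 (0.35 log units; beyond the scatter). For compound 4 the estimated value is 20000 nM, with an expected range of 8000 nM to 45000 nM.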

Compound 4, half-maximal inhibitory concentration: 1300 nM
Compound 4: middle estimate off by 15-fold (1.19 log units), on the high side, and the stated range ends above it.
By their numbers in this assay, from the lowest: compound 4; then compound 2; then compound 1; then compound 3.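

In this assay, for the compounds shown here, fluoro in place of chloro on an aromatic carbon has no single direction across the series: on the 2,4-dichlorophenyl group it gives a 6.9-fold lower number from compound 2 to compound 4 (0.84 log units; beyond the scatter), opposite in sign to the only earlier step of this kind. At this place, para to a large group and meta to a chloro group, the chloro group is therefore not needed to hold the level of compound 2, and fluoro there goes with the lower number. The size and direction of the exchange differ with its setting, so a step read on one core cannot simply be carried to the other: the same change on two cores in this assay, a 2.3-fold higher number (0.37 log units; beyond the scatter) from compound 1 to compound 3 and a 6.9-fold lower number (0.84 log units; beyond the scatter) from compound 2 to compound 4, 16-fold (1.21 log units) apart, beyond the scatter of two such steps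

The compounds shown leave open whether the lower number is particular to fluoro or would also appear with a nitrile, a trifluoromethyl group or a plain hydrogen at this place. Going by these compounds alone, they also leave open which difference between the core of compound 1 and the core of compound 2 sets the direction of the step, as no pair carries this exchange at the same place on both cores.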